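This account rests on a few compounds, and the source may have more. Where it says the series, first, only, none or still open, it means among the compounds named here.

Measured in a functional assay on MDA-MB-231 cells (Homo sapiens) for inhibition, read by MTT assay, with a stated time of 72 h, tested at 20 uM; on this read-out lower numbers stand for less inhibition and higher numbers for more inhibition at the one concentration tested (going by the name of the read-out):
- compound 1 `CNC(=O)c1cc(Oc2ccc(Nc3nccc(N4CCCC4)n3)cc2)ccn1`: 46.6%
- compound 2 `CN(C)c1ccc(C(=O)Nc2ccc(Oc3ncnc4ccsc34)cc2)cc1`: 10.4%
- compound 3 `c1cc(N2CCCCC2)nc(Nc2ccc(Oc3ncnc4sccc34)cc2)n1`: 40.4%

Compound 3 stands second highest of the three numbers. Its nearest neighbour is compound 1, whose number is higher by an amount within the usual scatter, so no order between compound 3 and compound 1 can be read from these two values. Compound 2 lies furthest off, its number being lower by a margin beyond the scatter.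

Compound 4 `CNC(=O)c1cc(Oc2ccc(Nc3nccc(N4CCCCC4)n3)cc2)ccn1` has not yet been measured in this assay. Set against compound 3, the change is a group of 10 heavy atoms (7 carbon, 2 nitrogen, 1 oxygen; one six-membered aromatic ring with 1 hetero atom) in place of a group of 9 heavy atoms (6 carbon, 2 nitrogen, 1 sulfur; one five-membered aromatic ring with 1 hetero atom, one six-membered aromatic ring with 2 hetero atoms), on an oxygen on an aromatic ring. For the measured compounds named here, compound 4 carries the same 2-(methylcarbamoyl)pyridin-4-yl on the oxygen as compound 1, the two differing elsewhere in the structure; no step between compound 1 and compound 4 has been measured, so the value of compound 1 serves only as a point of reference.

The two reference points, compound 1 giving 46.6% and compound 3 giving 40.4%, sit within the scatter of each other. The expected step is therefore small, a number 4.6 percentage points higher from compound 3 to compound 4 (within the scatter), with no direction beyond the scatter. Compound 4 is estimated at 45%, with a range from 25% to 65%.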

Compound 4, a percentage reported as inhibition, at one concentration (the size of the read-out at that concentration, not a potency): 52.3%
Beside the measured number, compound 4's estimate is 7.3 percentage points below it, and the stated range covers the measured number.
By their numbers in this assay, from the lowest: compound 2; then compounds 3, 1 and 4 (each within the scatter of the next, the first and the last beyond it).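

In this assay, placing 2-(methylcarbamoyl)pyridin-4-yl on the oxygen on an aromatic ring, where compound 3 carries a fused bicyclic group with a five-membered and a six-membered aromatic ring, gives a number 11.9 percentage points higher from compound 3 to compound 4 (beyond the scatter) and is the only step at this place among the compounds shown. For the compounds shown here, this is a modest step, but it shows that the group on this oxygen can shift the read-out at the one concentration tested, which the earlier compounds could not show because none of them formed a one-place pair. Piperidin-1-yl in place of pyrrolidin-1-yl on an aromatic carbon gives a number 5.7 percentage points higher from compound 1 to compound 4 (within the scatter) and so does not separate these two rings, while nothing measured on these compounds accounts for either step.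

Going by these compounds, the step at the oxygen rests on a single pair carrying piperidin-1-yl, so whether it holds with pyrrolidin-1-yl or other groups on the aromatic carbon remains open, as does the share of the methylcarbamoyl in it as against the pyridine ring. Also open, on these data alone, is how a morpholine ring on that aromatic carbon, or a carboxylic acid in place of the methylcarbamoyl, would read in this assay at this single concentration.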